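Trading a Chain-End Ester for a Plain Hexyl Chain

The source may report more compounds than this note shows. Statements on the series, on what has been measured and on what is new or still open speak of the compounds shown alone.

Measured in a functional assay for inhibition; a higher number here means a weaker inhibitor, a lower number a stronger inhibitor
- Compound 1 `CCN(CC)C(=O)COc1ccc2c(=O)cc(-c3cc(C(C)(C)C)c(O)c(C(C)(C)C)c3)oc2c1` gives 3000 nM
- Compound 2 `CCOC(=O)CCCCOc1ccc2c(=O)cc(-c3cc(C(C)(C)C)c(O)c(C(C)(C)C)c3)oc2c1` gives 3000 nM

In this assay, within the data shown here, compound 2 stands level with compound 1, the only other compound measured. Compound 3 `CCCCCCOc1ccc2c(=O)cc(-c3cc(C(C)(C)C)c(O)c(C(C)(C)C)c3)oc2c1` keeps the shared core but ends its chain differently (ethyl in place of ethoxycarbonyl on a saturated chain carbon, four bonds along the chain from an oxygen on an aromatic ring): ethyl in place of ethoxycarbonyl on a saturated chain carbon, four bonds along the chain from an oxygen on an aromatic ring. Cut one bond further out, this reads 3-(ethoxycarbonyl)propyl to pentyl. Among the measured compounds shown here, one measured step bears on this change (no change at the digits printed from compound 1 to compound 2 (within the scatter)), and it stayed within the scatter. Both measured chains hold a carbonyl and compound 3 has none, so this evidence is thin. No step beyond the scatter is expected in either direction (no change at the digits printed from compound 2 to compound 3 (within the scatter)). Compound 3 is expected at 3000 nM in this assay, with an estimated range from 1000 nM to 9000 nM.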

Compound 3, half-maximal inhibitory concentration: 5000 nM
For compound 3 the middle estimate is 1.7-fold (0.22 log units) below the measured one; measured number inside the range.
By their numbers in this assay, from the lowest: compounds 1, 2 and 3 (each within the scatter of the next).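

In this assay, ethyl in place of ethoxycarbonyl removes the carbonyl and both hydrogen-bond acceptors of the ester, yet the result is a 1.7-fold higher number from compound 2 to compound 3 (0.22 log units; within the scatter), so at this position the ester is not needed to keep the number at this level. Pentyl in place of diethylcarbamoyl gives a 1.7-fold higher number from compound 1 to compound 3 (0.22 log units; within the scatter), so a chain with no carbonyl at all also stays level with the amide-bearing chain, and the three chains shown cannot be told apart in this assay. Nothing available here explains why these chains read alike.

The compounds shown leave open whether any group at this position can move the number beyond the scatter. A carboxylic acid or an amine at the chain end, or a much longer chain, would test that.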